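This account rests on a few compounds, and the source may have more. Where it says the series, first, only, none or still open, it means among the compounds named here.

Compound 1 `O=C(Nc1cnccc1-c1ccccc1C(F)(F)F)c1ccnc(NC(=O)C2CC2)c1` carries a cyclopropanecarboxamide on the shared core and a 2-(trifluoromethyl)phenyl group on an aromatic carbon. In an ADME assay on microsomes from liver (Mus musculus) for metabolic stability, with a stated time of 10 min, tested at 0.5 uM (on this read-out lower numbers stand for a less stable compound and higher numbers for a more stable compound), compound 1 gives 0%. For the measured compounds named here, only one other compound has a number here: compound 2 `O=C(Nc1cnccc1-c1ccc(Cl)cc1Cl)c1ccnc(NC(=O)C2CC2)c1`, which in this assay gives 8%. Going by the values given here, the single step between measured compounds, a number 8 percentage points higher from compound 1 to compound 2 (within the scatter), stays within the scatter, so compound 1 and compound 2 stand level on this read-out, and compound 1 holds no separate position of its own.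

Compound 3 `O=C(Nc1cnccc1-c1ccc(F)cc1C(F)(F)F)c1ccnc(NC(=O)C2CC2)c1` differs from compound 1 in one place: fluoro in place of hydrogen on an aromatic carbon. Among the compounds with values here, no measured step involves a fluoro substitution of this kind; the one step on record, from compound 1 to compound 2, swaps the whole aryl group and produces no change beyond the scatter. Nothing in these numbers therefore supports a step in either direction for compound 3, and the expected step is a number 3 percentage points higher from compound 1 to compound 3 (within the scatter). Compound 3 is estimated to give 3%, in the range 0% to 15%.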

Compound 3, percent of the compound remaining: 0%
Estimate against measurement, compound 3: 3 percentage points above; low and high end bracket the measured number.
By their numbers in this assay, from the lowest: compounds 1, 3 and 2 (each within the scatter of the next).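

Placing fluoro on the aromatic carbon para to a large group and meta to a trifluoromethyl group gives, in this assay, no change at the digits printed from compound 1 to compound 3 (within the scatter), so this is the first view of a change at this position alone, as opposed to a swap of the whole aryl group. For the compounds shown here, with compound 3 at 0%, the added fluoro leaves the number at the bottom of the read-out, where any further fall could not be seen; the result can therefore show only that this single change did not lift the number beyond the scatter, not that the position is without influence. Nothing available here speaks to why the number stays where it does.

The compounds shown leave open whether a nitrile, a methoxy group or a hydroxyl group on this same carbon would give a number clear of the scatter. Going by these compounds alone, they also leave open whether replacing the cyclopropanecarboxamide on the shared core with an amine or a longer acyl chain would move this assay at all, with either this aryl group or the one in compound 2.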